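The source may hold more compounds than are shown below. What is called first, only, known or untested is meant among the compounds shown, and "the series" means these compounds.

Three compounds built on one shared core were tested in an ADME assay on 184B5 cells (Homo sapiens) for antiproliferative activity, read by sulforhodamine B assay, with a stated time of 72 h; a lower number here means a stronger inhibitor, a higher number a weaker inhibitor. Compound 1 `COc1ccc2nc(Cl)c(/C=C\c3cccc(C(F)(F)F)c3)cc2c1` gives 5580 nM, and compound 2 `COc1ccc2nc(Cl)c(/C=C\c3cc(C(F)(F)F)cc(C(F)(F)F)c3)cc2c1` gives 7970 nM. Compound 3 `COc1ccc2nc(Cl)c(/C=C\c3ccc(C(F)(F)F)cc3C(F)(F)F)cc2c1` gives no number, only a limit, > 50000 nM, which is the limit of > 50000 nM in this assay, at which 1 of the 3 values shown sits. The difference between the cores of compound 2 and compound 3 is not broken down here. From compound 2 to compound 1 the change is hydrogen in place of trifluoromethyl on an aromatic carbon, and it made a 1.4-fold lower number from compound 2 to compound 1 (0.15 log units; within the scatter). Compound 4 `COc1ccc2nc(Cl)c(/C=C\c3ccccc3C(F)(F)F)cc2c1` is not yet measured; it arises from compound 3 by the same kind of change, (hydrogen in place of trifluoromethyl on an aromatic carbon), though the surroundings differ: in compound 1 the spot is meta to a large group, in compound 4 it is para to a large group. Compound 4 is expected to show an at least 1.6-fold lower number from compound 3 to compound 4 (0.22 log units; that floor lies within the scatter) in this assay, with an estimated value of 30000 nM, likely between 8000 nM and 150000 nM. That expectation rests on the small step of a 1.4-fold lower number from compound 2 to compound 1 (0.15 log units; within the scatter), while the starting point stays uncertain since compound 3 gave only a limit.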

Compound 4, half-maximal inhibitory concentration: 5310 nM
Compound 4: middle estimate off by 5.6-fold (0.75 log units), on the high side, outside the stated range (below it).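

Replacing trifluoromethyl with hydrogen on an aromatic carbon gave, in this assay, an at least 9.4-fold lower number from compound 3 to compound 4 (0.97 log units; beyond the scatter). This change therefore did not carry over from one core to the other with the same size of step: the same change on two cores in this assay, a 1.4-fold lower number (0.15 log units; within the scatter) from compound 2 to compound 1 and an at least 9.4-fold lower number (0.97 log units; beyond the scatter) from compound 3 to compound 4, at least 6.5-fold (0.81 log units) apart, beyond the scatter of two such steps. From the compounds shown here alone, compound 3 has only a limit, > 50000 nM, so the full size of its step stays unknown, and two pairs of compounds give no rule for predicting the step on any other core.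

The compounds shown leave open how this assay would respond to other groups on the same aromatic ring, such as an amine or a carboxylic acid. They also leave open whether replacing trifluoromethyl with hydrogen would give a large or a small step on further cores.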